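The source may hold more compounds than are shown below. What is called first, only, known or untested is meant among the compounds shown, and "the series" means these compounds.

Measured so far:
compound 1 `O=C(O)Cc1sc(C(Cc2ccccc2)c2ccccc2)nc1-c1ccc(Cl)cc1`: 510 nM
compound 2 `O=C(O)Cc1sc(C(c2ccc(F)cc2)c2ccc(F)cc2)nc1-c1cccc(F)c1`: 18 nM
compound 3 `O=C(O)Cc1sc(C(c2ccc(F)cc2)c2ccc(F)cc2)nc1-c1cc(F)cc(F)c1`: 340 nM

In an in vitro functional assay on HEK285-7 cells for antagonist activity at prostaglandin D2 receptor 2 (Homo sapiens), read by BRET and beta-arrestin recruitment (a higher number here means a weaker inhibitor, a lower number a stronger inhibitor), compound 3 gives 340 nM, the second highest of the three numbers. It stands nearest compound 1, which gives 510 nM, and furthest from compound 2, which gives 18 nM. Compound 4 `CS(=O)(=O)Nc1cccc(-c2nc(C(c3ccc(F)cc3)c3ccc(F)cc3)sc2CC(=O)O)c1` has not yet been measured. It differs from compound 3 in one place: 3-(methanesulfonamido)phenyl in place of 3,5-difluorophenyl on an aromatic carbon. Among the compounds with values here, no measured step swaps this ring for one carrying a methanesulfonamide, so there is no direct precedent. Within the data shown here, the one step that bears on it is a 19-fold higher number from compound 2 to compound 3 (1.28 log units; beyond the scatter), which shows that what sits on this ring, at this place on the shared core, can move the number a long way. The change to compound 4 is a larger one than a fluoro in place of hydrogen, so a step well beyond the scatter is expected, though its direction is uncertain. On balance a lower number is expected for compound 4, a 3.4-fold lower number from compound 3 to compound 4 (0.53 log units; beyond the scatter). Compound 4 is therefore estimated at 100 nM, with a range from 15 nM to 700 nM.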

Compound 4, half-maximal inhibitory concentration: 370 nM
Estimate against measurement, compound 4: 3.7-fold (0.57 log units) below, within the range that was stated.
By their numbers in this assay, from the lowest: compound 2; then compounds 3, 4 and 1 (each within the scatter of the next).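

In this assay, putting 3-(methanesulfonamido)phenyl where the 3,5-difluorophenyl stood gives a 1.1-fold higher number from compound 3 to compound 4 (0.04 log units; within the scatter) and so no measurable change, even though the entering group is larger and brings a hydrogen-bond donor and acceptors that the leaving group lacks. Methanesulfonamido in place of fluoro gives a 21-fold higher number from compound 2 to compound 4 (1.31 log units; beyond the scatter), so the large rise first seen with a second fluoro also appears with a very different group. Nothing in the data shown explains why these two different rings give numbers within the scatter of each other.

Within the data shown here, still open is how a plain phenyl, or a chloro or methoxy group on this ring, would compare with the single fluoro of compound 2. Also open, as far as these compounds go, is whether a methyl on the sulfonamide nitrogen, or an amine or a carboxylic acid in place of methanesulfonamido, would move the number at all.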